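Para Substituent Exchange on a Shared Dienone Core

The source may hold more compounds than are shown below. What is called first, only, known or untested is meant among the compounds shown, and "the series" means these compounds.

Measured compounds:
compound 1, `C=C(C/C(=C\c1ccc(Cl)cc1)C(=O)c1ccccc1)C(=O)c1ccccc1`: 20000 nM
compound 2, `C=C(C/C(=C\c1ccc(F)cc1)C(=O)c1ccccc1)C(=O)c1ccccc1`: 19000 nM

Compound 1 and compound 2 share one core and differ only in the group on the aromatic ring. In a functional assay on WiDr cells (Homo sapiens) for inhibition, read by sulforhodamine B assay, with a stated time of 48 h (a higher number here means a weaker inhibitor of growth, a lower number a stronger inhibitor of growth), compound 1 gives 20000 nM, while compound 2 gives 19000 nM. Among the measured compounds shown here, the single step available, a 1.1-fold lower number from compound 1 to compound 2 (0.02 log units; within the scatter), is within the scatter, so the two compounds cannot be put in any order. Compound 2 carries the lower of the two numbers, but its gap to compound 1 is too small to mean anything.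

Compound 3, `C=C(C/C(=C\c1ccc(OC)cc1)C(=O)c1ccccc1)C(=O)c1ccccc1`, is derived from compound 2 by the change (methoxy in place of fluoro on an aromatic carbon). For the measured compounds named here, only the step from compound 1 to compound 2 bears on this place on the ring, and it showed no movement beyond the scatter when one halogen replaced another. Going by the values given here, no measured compound carries a methoxy anywhere, so the data give no direct guide to it. Compound 3 is therefore expected to sit close to compound 2, with a step of about a 1.1-fold higher number from compound 2 to compound 3 (0.02 log units; within the scatter). The estimate for compound 3 in this assay is 20000 nM, within a range from 7000 nM to 60000 nM.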

Compound 3, concentration for 50% growth inhibition: 470 nM
For compound 3 the middle estimate is 43-fold (1.63 log units) above the measured one; measured number outside the range, below it.
By their numbers in this assay, from the lowest: compound 3; then compounds 2 and 1 (each within the scatter of the next).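

In this assay, the change from 4-fluorophenyl to 4-methoxyphenyl gives a 40-fold lower number from compound 2 to compound 3 (1.61 log units; beyond the scatter), and methoxy in place of chloro at the same aromatic carbon gives a 43-fold lower number from compound 1 to compound 3 (1.63 log units; beyond the scatter). This place on the ring, para to a large group, therefore responds strongly to the group it carries, which the exchange of one halogen for the other did not reveal. Compound 3 stands apart from the two halogen compounds with steps beyond the scatter to both, making it the strongest inhibitor of growth of the three, while compound 1 and compound 2 remain together and cannot be ordered. No measurement available here accounts for the size of this step, so the result stands as an observation without an explanation.

Going by these compounds, what a hydroxy, ethoxy or dimethylamino group would do at this same place remains open, so it cannot be said how far the effect extends beyond methoxy itself. On these data alone, it is also open whether a methoxy group on either of the other two aromatic rings of the shared core would produce a step of similar size.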